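The compounds below may be only part of what the source reports. "The series", "measured", "known", "first", "only" and "open" are said of these compounds alone.

Working notes on the series. In an assay on brain for binding affinity to Neuronal acetylcholine receptor; alpha4/beta2 (Rattus norvegicus), read by radioligand binding (on this read-out lower numbers stand for stronger inhibition and higher numbers for weaker inhibition), compound 1 `Fc1ccc(OC[C@@H]2CCN2)cn1` gives 0.057 nM. Compound 2 `COc1ccc(OC[C@@H]2CCN2)cn1` gives 1.3 nM in this assay. Compound 3 `Brc1cncc(OC[C@@H]2CCN2)c1` gives 0.18 nM in this assay; of the three numbers shown it is the second highest, with compound 1 nearest and compound 2 furthest, both gaps beyond the scatter.

Compound 4 `CCOc1cncc(OC[C@@H]2CCN2)c1` is not yet measured. It differs from compound 3 by ethoxy in place of bromo on an aromatic carbon. Among the compounds with values here, the only measured step that bears on this is a 23-fold higher number from compound 1 to compound 2 (1.36 log units; beyond the scatter), where an alkoxy group entering in place of a halogen on the shared core raised the number strongly. The present change is of the same kind, halogen out and alkoxy in, although neither the leaving group nor the entering group nor the place on the ring is identical, so the size of that step is taken only as a rough guide. On that basis an upward step is expected, an 8.3-fold higher number from compound 3 to compound 4 (0.92 log units; beyond the scatter), likely somewhat smaller than the measured one. Compound 4 is therefore expected to give about 1.5 nM in this assay, within a range of 0.3 nM to 8 nM.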

Compound 4, inhibition constant: 0.039 nM
For compound 4 the middle estimate is 38-fold (1.59 log units) above the measured one; measured number outside the range, below it.
By their numbers in this assay, from the lowest: compounds 4 and 1 (each within the scatter of the next); then compound 3; then compound 2.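

In this assay, ethoxy in place of bromo on an aromatic carbon two atoms from the ring nitrogen gives a 4.6-fold lower number from compound 3 to compound 4 (0.66 log units; beyond the scatter), so at this position the exchange of a halogen for an alkoxy group, with 3 heavy atoms entering where 1 leaves, does not raise the number. Within the data shown here, the one earlier step of this kind, a 23-fold higher number from compound 1 to compound 2 (1.36 log units; beyond the scatter), runs the other way, so across these two pairs, which differ in the groups exchanged and in the place on the ring, halogen-to-alkoxy exchange has no single direction.

From the compounds shown here alone, whether a longer chain such as propoxy, or an amine or a carboxylic acid, would keep the number low at this position stays open. Also open, going by these compounds, is whether ethoxy in the place of the fluoro group of compound 1 would follow compound 2 or compound 4. Nothing on hand accounts for the opposite directions of the two steps.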